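The compounds below may be only part of what the source reports. "The series", "measured", "known", "first", "only" and "open" are said of these compounds alone.

Compound 1 `Cc1c(C(=O)Nc2ccc(Oc3ccnc4[nH]ccc34)c(F)c2)nnn1-c1ccccc1F`: 390 nM
Compound 2 `Cc1c(C(=O)Nc2ccc(Oc3ccnc4[nH]ccc34)c(F)c2)nnn1-c1ccc(F)cc1`: 150 nM
Compound 3 `Cc1c(C(=O)Nc2ccc(Oc3ccnc4[nH]ccc34)c(F)c2)nnn1-c1ccc(F)c(Cl)c1`: 730 nM

In a functional assay on A549 cells (Homo sapiens) for cytotoxicity, read by MTT assay, with a stated time of 72 h (on this read-out higher numbers stand for weaker inhibition and lower numbers for stronger inhibition), compound 2 gives the lowest of the three numbers, and both steps that reach it, a 2.6-fold lower number from compound 1 to compound 2 (0.41 log units; beyond the scatter) and a 4.9-fold higher number from compound 2 to compound 3 (0.69 log units; beyond the scatter), lie beyond the scatter. Compound 4 `Cc1c(C(=O)Nc2ccc(Oc3ccnc4[nH]ccc34)cc2)nnn1-c1ccc(F)cc1` differs from compound 2 by hydrogen in place of fluoro on an aromatic carbon. Among the measured compounds shown here, none of the measured steps touches this ring: a 2.6-fold lower number from compound 1 to compound 2 (0.41 log units; beyond the scatter), a 1.9-fold higher number from compound 1 to compound 3 (0.27 log units; within the scatter) and a 4.9-fold higher number from compound 2 to compound 3 (0.69 log units; beyond the scatter) all concern the aryl group on the aromatic nitrogen, and only in a 4.9-fold higher number from compound 2 to compound 3 (0.69 log units; beyond the scatter) does a halogen change on an aromatic carbon, there entering rather than leaving. For the measured compounds named here, with no matching precedent, for compound 4 the step is expected to be a 1.7-fold higher number from compound 2 to compound 4 (0.22 log units; within the scatter), within the scatter. Compound 4 is therefore estimated at 250 nM, in the range 100 nM to 700 nM.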

Compound 4, half-maximal inhibitory concentration: 220 nM
Compound 4: middle estimate off by 1.1-fold (0.06 log units), on the high side; the measured number falls inside the stated range.
By their numbers in this assay, from the lowest: compounds 2, 4, 1 and 3 (each within the scatter of the next, the first and the last beyond it).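

In this assay, among the compounds shown here, this is the first step on the ring carrying the fluoro, and hydrogen in place of fluoro, ortho to a large group and meta to a large group, gives a 1.5-fold higher number from compound 2 to compound 4 (0.17 log units; within the scatter). The fluoro at this position is therefore not needed to hold the number, whereas the halogen change on the aryl group on the aromatic nitrogen gives a 4.9-fold higher number from compound 2 to compound 3 (0.69 log units; beyond the scatter). No supporting measurement explains this result. The compounds shown hold only fluoro and hydrogen at this position. As far as these compounds go, whether a methoxy group, a nitrile or an amine there would move the number beyond the scatter stays open.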